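The source may hold more compounds than are shown below. What is called first, only, known or untested is meant among the compounds shown, and "the series" means these compounds.

Compound 1 `CCCCCCCCc1ccc(OCC(=O)Cn2ncnn2)cc1`: < 5%
Compound 2 `CCCCCCCCc1ccc(OCC(=O)Cn2nnnc2-c2cccc(Cl)c2)cc1`: 41%

In an ADME assay on S9 fraction from liver (Rattus norvegicus) for metabolic stability, read by LC-MS, using NADPH, with a stated time of 30 min (on this read-out higher numbers stand for a more stable compound and lower numbers for a less stable compound), compound 1 shows < 5%, which is a limit and not a number. Among the measured compounds shown here, compound 2 gives 41%, the only actual number so far. Compound 3 `CCCCCCCCc1ccc(OCC(=O)Cn2nnnc2Cc2ccccc2)cc1` has benzyl in place of 3-chlorophenyl on an aromatic carbon of the shared core (benzyl in place of 3-chlorophenyl on an aromatic carbon). For the measured compounds named here, the two groups are the same size by heavy-atom count, and no measured pair isolates this change, so only a modest fall in this assay is expected, an estimated a number 11 percentage points lower from compound 2 to compound 3 (beyond the scatter). For compound 3 the expected value is 30%, with an estimated range of 10% to 52%.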

Compound 3, percent of the compound remaining: 26%
Compound 3: middle estimate off by 4 percentage points, on the high side; measured number inside the range.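

In this assay, among the compounds shown here, benzyl in place of 3-chlorophenyl gives a number 15 percentage points lower from compound 2 to compound 3 (beyond the scatter), the first measured change at this position. The two groups have the same heavy-atom count, so equal size does not make them equal on this read-out. Compound 2 and compound 3 both give actual numbers, so this step can be read in full, clear of the one limit in the set: the limit of < 5% in this assay, at which 1 of the 3 values shown sits.

A single step cannot separate the part played by the chlorine from that of the extra carbon in benzyl. Going by these compounds, how plain phenyl or an amine at this position would fare remains open.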